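A few compounds are considered here, and "the series" means these few. Any claim that something is new, unique, unknown or untested is made for them only; others in the source may bear on it.

Measured compounds in an assay on isolated protein for inhibition of leukotriene B4 receptor 1 (Homo sapiens), tested at 10 uM; a lower number here means less inhibition, a higher number more inhibition at the concentration tested (going by the name of the read-out):
compound 1 `CSCc1cc(C(C)=O)c(O)cc1OCCCCCCC#N`: 97%
compound 2 `CC(=O)c1cc(CO)c(OCCCCCCC#N)cc1O`: 40%
compound 3 `C=CCc1cc(C(C)=O)c(O)cc1OCCCCCCC#N`: 97%

Compound 3 stands level with compound 1, the two together giving the highest numbers of the three; compound 2 lies well apart, the gap being a number 57 percentage points higher from compound 2 to compound 3 (beyond the scatter).

Compound 4 `C=CCc1cc(C(C)=O)c(O)cc1OCCCCCCC` differs from compound 3 in one place: methyl in place of cyano on a saturated chain carbon, six bonds along the chain from an oxygen on an aromatic ring. For the measured compounds named here, none of the measured steps touches this part of the molecule: a number 57 percentage points lower from compound 1 to compound 2 (beyond the scatter), no change at the digits printed from compound 1 to compound 3 (within the scatter) and a number 57 percentage points higher from compound 2 to compound 3 (beyond the scatter) all concern the group on the saturated chain carbon bound to an aromatic carbon, not the chain end. Going by the values given here, no measured step therefore bears on this change, and the expected step of a number 12 percentage points lower from compound 3 to compound 4 (beyond the scatter) rests on no comparison. The estimate for compound 4 in this assay is 85%, expected to fall between 55% and 98%.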

Compound 4, a percentage reported as inhibition, at one concentration (the size of the read-out at that concentration, not a potency): 31%
The estimate for compound 4 lay 54 percentage points above the measured number, outside the stated range (below it).
By their numbers in this assay, from the lowest: compounds 4 and 2 (each within the scatter of the next); then compounds 1 and 3 (each within the scatter of the next).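

In this assay methyl in place of cyano, on a saturated chain carbon six bonds along the chain from an oxygen on an aromatic ring, gives a number 66 percentage points lower from compound 3 to compound 4 (beyond the scatter) and thus shows that the read-out depends on the chain end. Until now, only the group on the saturated chain carbon bound to an aromatic carbon had been seen to change the number. No measurement here accounts for this step.

Going by these compounds, whether the nitrile alone supports the high number remains open. A carboxylic acid or an amine at the chain end, or a longer chain ending in nitrile, would test this.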